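Aryl urea series: aminopyrimidine ether substituent and TNNI3K inhibition

This account rests on a few compounds, and the source may have more. Where it says the series, first, only, none or still open, it means among the compounds named here.

Measured compounds:
compound 1 `CNc1cc(Oc2ccc(NC(=O)Nc3cccc(C(F)(F)F)c3)cc2)ncn1`: 40 nM
compound 2 `CN(C)c1cc(Oc2ccc(NC(=O)Nc3cccc(C(F)(F)F)c3)cc2)ncn1`: 2500 nM

In an assay on isolated protein for inhibition of serine/threonine-protein kinase TNNI3K (Homo sapiens) (a lower number here means a stronger inhibitor, a higher number a weaker inhibitor), compound 1 gives 40 nM and compound 2 gives 2500 nM. Compound 2 stands highest of the two numbers, its nearest neighbour being compound 1, reached by a 63-fold higher number from compound 1 to compound 2 (1.80 log units; beyond the scatter); that step is the only one measured so far and it is large, the methyl on the ring-attached nitrogen taking the number far up.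

Compound 3 `C[C@H](O)CNc1cc(Oc2ccc(NC(=O)Nc3cccc(C(F)(F)F)c3)cc2)ncn1` is not yet measured. It differs from compound 2 by (2-hydroxypropyl)amino in place of dimethylamino on an aromatic carbon. For the measured compounds named here, the change brings back a hydrogen on that nitrogen while adding a longer chain bearing a hydroxyl, so the single measured step bears on it in reverse: compound 1 carries a hydrogen there and gives 40 nM, compound 2 does not and gives 2500 nM. A large step downward in this assay is therefore expected for compound 3, of about a 50-fold lower number from compound 2 to compound 3 (1.70 log units; beyond the scatter), the chain lengthening being untested here. The expected value for compound 3 is 50 nM, within 12 nM to 250 nM.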

Compound 3, half-maximal inhibitory concentration: 32 nM
Estimate against measurement, compound 3: 1.6-fold (0.19 log units) above; the measured number falls inside the stated range.
By their numbers in this assay, from the lowest: compounds 3 and 1 (each within the scatter of the next); then compound 2.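

Working notes on the substituent at this aromatic carbon. In this assay, (2-hydroxypropyl)amino in place of dimethylamino gives a 78-fold lower number from compound 2 to compound 3 (1.89 log units; beyond the scatter), so the large loss seen with dimethylamino does not extend to every larger group at this position. The step of a 1.3-fold lower number from compound 1 to compound 3 (0.10 log units; within the scatter) adds 1-hydroxyethyl to the saturated chain carbon bound to the nitrogen with no change that can be told from scatter, so this position accepts the added chain and its defined stereocentre without a measurable cost in this assay. Among the three compounds, the two that keep a hydrogen on that nitrogen, compound 1 and compound 3, sit together and compound 2, which has none, stands apart, with no contrary case among them, though nothing available accounts for that split.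

The plain propylamino group and the opposite enantiomer of the (2-hydroxypropyl)amino group would show whether the hydroxyl or its configuration matters at all. A longer chain ending in an amine or a carboxylic acid, and a 2-hydroxypropyl chain with a methyl on the same nitrogen, would test how far the chain can grow and whether the hydrogen on that nitrogen is what separates compound 2 from the others.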